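The compounds below may be only part of what the source reports. "The series", "measured", "known", "first", "only" and "open" are said of these compounds alone.

Series notes, two measured compounds so far. Compound 2 `O=C(Nc1ccc(-n2cc(-c3ccncc3)c(-c3ccc(Cl)c(O)c3)n2)cc1)Nc1ccc(Cl)c(C(F)(F)F)c1` in a functional assay on UACC-62 cells (Homo sapiens) for antiproliferative activity, read by sulforhodamine B assay, with a stated time of 48 h (a lower number here means a stronger inhibitor, a higher number a weaker inhibitor), gives 1700 nM, the lower of the two numbers at hand. Compound 1 `COc1cc(-c2nn(-c3ccc(NC(=O)c4ccc(Cl)c(Cl)c4)cc3)cc2-c2ccncc2)ccc1Cl` in this assay gives 6340 nM. Compound 1 and compound 2 differ in more than one place, so the gap between them is not assigned to any single change; what the two values show is that compound 2 sits at the lower number, with a gap beyond the scatter.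

Compound 3 `O=C(Nc1ccc(-n2cc(-c3ccncc3)c(-c3ccc(Cl)c(O)c3)n2)cc1)c1ccc(Cl)c(Cl)c1` is the next compound to be measured. It differs from compound 2 in one place: 3,4-dichlorophenyl in place of (4-chloro-3-(trifluoromethyl)phenyl)amino on a carbonyl carbon. With that change compound 3 carries the same 3,4-dichlorophenyl on the carbonyl carbon as compound 1, while the rest of compound 2 is kept. Among the compounds with values here, no single-change step between measured compounds is available, so the size of the step to be expected rests on the two values alone and on the resemblance of compound 3 to both. Compound 3 is expected to move towards a higher number, by an estimated 1.9-fold higher number from compound 2 to compound 3 (0.27 log units; within the scatter). Compound 3 is estimated at 3200 nM, with a range from 1100 nM to 9500 nM.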

Compound 3, half-maximal inhibitory concentration: 3220 nM
For compound 3 the middle estimate is 1.0-fold (0.00 log units) below the measured one; the measured number falls inside the stated range.
By their numbers in this assay, from the lowest: compounds 2, 3 and 1 (each within the scatter of the next, the first and the last beyond it).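

In this assay, 3,4-dichlorophenyl in place of (4-chloro-3-(trifluoromethyl)phenyl)amino on a carbonyl carbon gives a 1.9-fold higher number from compound 2 to compound 3 (0.28 log units; within the scatter), so this first single-change reading at that position cannot be told from the scatter, even though the amino nitrogen and its hydrogen-bond donor leave with the group. At the second position, hydrogen in place of methyl on an oxygen on an aromatic ring gives a 2.0-fold lower number from compound 1 to compound 3 (0.29 log units; within the scatter), so neither change, taken alone, produces a step beyond the scatter in these compounds. The measurements at hand offer nothing that explains the size of either step.

As far as these compounds go, it remains open whether a group of a different kind on the carbonyl carbon, such as a piperidine or a longer alkyl chain, would produce a step beyond the scatter, and whether an ethyl group on the oxygen would do so at the second position. From the compounds shown here alone, each change is also read against one background only, so the step for hydrogen in place of methyl with (4-chloro-3-(trifluoromethyl)phenyl)amino on the carbonyl carbon is still unknown.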